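A few compounds are considered here, and "the series" means these few. Any claim that something is new, unique, unknown or untested is made for them only; others in the source may bear on it.

Compound 1, `N#Cc1c(NCc2ccccc2)c(F)c2nc(N)nc(N)c2c1F`: > 1000 ug/mL
Compound 2, `N#Cc1c(NCc2ccccc2)c(Cl)c2nc(N)nc(N)c2c1NCc1ccccc1`: > 1000 ug/mL

Both measured compounds were tested in a functional assay on A549 cells (Homo sapiens) for cytotoxicity, read by MTT assay; a lower number here means a stronger inhibitor, a higher number a weaker inhibitor. For compound 1 the reading of > 1000 ug/mL is a limit of the assay and not a number. For compound 2 the reading of > 1000 ug/mL is likewise a limit of the assay and not a number. Where compound 2 stands is therefore told only by the limit of > 1000 ug/mL in this assay, at which 2 of the 2 values shown sit. Compound 3, `N#Cc1c(NCc2ccccc2)c(F)c2nc(N)nc(N)c2c1NCc1ccccc1`, has not yet been measured in this assay. The change from compound 2 to compound 3 is fluoro in place of chloro on an aromatic carbon. Among the compounds with values here, no step between two measured compounds is available, so no measured step size can be drawn on; the step that the limit leaves unreadable from compound 2 to compound 3 that the estimate means is expected to be none beyond the usual scatter. For compound 3 a value of 1500 ug/mL is expected, within 700 ug/mL to 3000 ug/mL, and most likely the assay again reports only a limit.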

Compound 3, half-maximal inhibitory concentration: 13.9 ug/mL
For compound 3 the middle estimate is 110-fold (2.03 log units) above the measured one; the measured number lies below the stated range.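

In this assay, fluoro in place of chloro, para to a benzylamino group, is far from a silent exchange: it gives an at least 71-fold lower number from compound 2 to compound 3 (1.85 log units; beyond the scatter). The second benzylamino group counts as well, with an at least 71-fold lower number from compound 1 to compound 3 (1.85 log units; beyond the scatter), so among these three compounds a measurable reading appears only where that fluoro and both benzylamino groups occur together. Both steps give only a minimum size, since each starts from a limit: the limit of > 1000 ug/mL in this assay, at which 2 of the 3 values shown sit.

The compounds shown leave open whether bromo or a plain hydrogen at the same place would behave like fluoro or like chloro. They also leave open whether a shorter chain such as methylamino, or a carboxylic acid, could stand in for either benzylamino group and keep the reading.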